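A few compounds are considered here, and "the series" means these few. Any claim that something is new, unique, unknown or untested is made for them only; others in the source may bear on it.

Series notes. In a functional assay on CHO cells with adenosine receptor A1 (Homo sapiens) as the target, read by cAMP accumulation and immunoassay, with a stated time of 6 min, tested at 0.01 uM (on this read-out lower numbers stand for a stronger effect and higher numbers for a weaker effect at the one concentration tested), compound 1 `Nc1scc(CN2CCN(c3ccc(Cl)cc3F)CC2)c1C(=O)c1ccc(Cl)cc1` gives -9.2%, compound 2 `Nc1scc(CN2CCN(c3c(F)cccc3F)CC2)c1C(=O)c1ccc(Cl)cc1` gives -12% and compound 3 `Nc1scc(CN2CCN(c3ccccc3Cl)CC2)c1C(=O)c1ccc(Cl)cc1` gives -2.1%. Compound 3 holds the highest of the three numbers, yet both a number 7.1 percentage points higher from compound 1 to compound 3 (within the scatter) and a number 9.9 percentage points higher from compound 2 to compound 3 (within the scatter) stay within the scatter, so the three compounds cannot be told apart on these figures. Compound 4 `Nc1scc(CN2CCN(c3ccc(Cl)c(Cl)c3)CC2)c1C(=O)c1ccc(Cl)cc1` differs from compound 3 by 3,4-dichlorophenyl in place of 2-chlorophenyl on an amine nitrogen in a ring. The measured steps that bear on this change are the earlier swaps of the aryl group on the same ring nitrogen: a number 2.8 percentage points lower from compound 1 to compound 2 (within the scatter), a number 7.1 percentage points higher from compound 1 to compound 3 (within the scatter) and a number 9.9 percentage points higher from compound 2 to compound 3 (within the scatter), none of them beyond the scatter. For compound 4 a step of a number 3.9 percentage points lower from compound 3 to compound 4 (within the scatter) is therefore expected, again nothing beyond the scatter. Compound 4 is estimated at -6%, with a range from -22% to 10%.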

Compound 4, a percentage reported as activity, at one concentration (the size of the read-out at that concentration, not a potency): -1.2%
Compound 4: the middle estimate sits 4.8 percentage points below what was measured, and the stated range covers the measured number.
By their numbers in this assay, from the lowest: compounds 2, 1, 3 and 4 (each within the scatter of the next, the first and the last beyond it).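

On the ring nitrogen in this assay, 3,4-dichlorophenyl reads level with the other chlorine-bearing aryl groups, with a number 0.9 percentage points higher from compound 3 to compound 4 (within the scatter) and a number 8 percentage points higher from compound 1 to compound 4 (within the scatter) both inside the scatter. For the compounds shown here, its exchange for 2,6-difluorophenyl gives the first step at this position to pass the scatter, a number 10.8 percentage points higher from compound 2 to compound 4 (beyond the scatter), and that step is only modest. No measurement at hand accounts for this step. Still open, on these data alone, is whether a methoxy group, an amine or a carboxylic acid on this phenyl ring would give a larger step.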